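The compounds below may be only part of what the source reports. "The series", "measured", "known", "first", "only" and "open" are said of these compounds alone.

Among the measured compounds shown here, in a functional assay on cells (Platelet) for inhibition (a lower number here means a stronger inhibitor, a higher number a weaker inhibitor), compound 1 `O=c1cc(N2CCNCC2)nc2sc(-c3ccccc3)nn12` gives 3000 nM, the lowest of the two numbers so far. Compound 2 `O=C(O)c1ccc(-c2nn3c(=O)cc(N4CCNCC4)nc3s2)cc1` gives 6500 nM. Compound 3 `O=C(O)c1cccc(-c2nn3c(=O)cc(N4CCNCC4)nc3s2)c1` differs from compound 1 by carboxy in place of hydrogen on an aromatic carbon, with the carboxy meta to a large group. For the measured compounds named here, the one measured step that bears on this is a 2.2-fold higher number from compound 1 to compound 2 (0.34 log units; beyond the scatter), a modest change that also puts carboxy in place of hydrogen on an aromatic carbon, but at a different carbon of that ring. A similar modest rise is therefore expected, an estimated 1.8-fold higher number from compound 1 to compound 3 (0.26 log units; within the scatter) in this assay. Compound 3 is estimated at 5500 nM, within an expected range of 2200 nM to 13000 nM.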

Compound 3, half-maximal inhibitory concentration: 80000 nM
Beside the measured number, compound 3's estimate is 15-fold (1.16 log units) below it, outside the stated range (above it).
By their numbers in this assay, from the lowest: compound 1; then compound 2; then compound 3.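

In this assay the same change, carboxy in place of hydrogen, does not cost the same everywhere on this ring: meta to a large group it gives a 27-fold higher number from compound 1 to compound 3 (1.43 log units; beyond the scatter) and is large, while at a different carbon of that ring it gave only a 2.2-fold higher number from compound 1 to compound 2 (0.34 log units; beyond the scatter) and was modest. The place of the carboxy therefore matters far more than the first pair could show. Nothing available explains this gap. Still open, from the compounds shown here alone, is whether a methyl ester, an amide or a simple methyl group at this same carbon would raise the number as much as the carboxylic acid does.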